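This account rests on a few compounds, and the source may have more. Where it says the series, first, only, none or still open, it means among the compounds named here.

Measured in a functional assay on A549 cells (Homo sapiens) for antiproliferative activity, read by MTT assay, with a stated time of 48 h (a lower number here means a stronger inhibitor, a higher number a weaker inhibitor), so far:
compound 1 `COc1ccc(-c2nn(-c3ccccc3)cc2C(Nc2nc3ccccc3s2)c2c(O)ccc3ccccc23)cc1` gives 26200 nM
compound 2 `O=[N+]([O-])c1ccc(-c2nn(-c3ccccc3)cc2C(Nc2nc3ccccc3s2)c2c(O)ccc3ccccc23)cc1` gives 41300 nM

Compound 2 stands within the scatter of compound 1, so the two values cannot be ranked. Compound 3 `Oc1ccc2ccccc2c1C(Nc1nc2ccccc2s1)c1cn(-c2ccccc2)nc1-c1cccc(Cl)c1` differs from compound 2 by 3-chlorophenyl in place of 4-nitrophenyl on an aromatic carbon on an aromatic carbon of a five-membered aromatic ring with 2 nitrogen. For the measured compounds named here, one measured step bears on this change: a 1.6-fold higher number from compound 1 to compound 2 (0.20 log units; within the scatter) with nitro in place of methoxy on an aromatic carbon. That step alters the same substituent and stays within the scatter. Going by the values given here, no compound carrying 3-chlorophenyl or any other chlorine has been measured, so the data offer only weak guidance. As far as these compounds go, no step beyond the scatter is therefore expected in this assay and the direction remains open. The expected change is a 1.3-fold lower number from compound 2 to compound 3 (0.11 log units; within the scatter) and it rests on that single step. Compound 3 is estimated at 32000 nM with an expected range from 14000 nM to 70000 nM for a single measurement.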

Compound 3, half-maximal inhibitory concentration: 20400 nM
Compound 3: the middle estimate sits 1.6-fold (0.20 log units) above what was measured; the measured number falls inside the stated range.
By their numbers in this assay, from the lowest: compounds 3, 1 and 2 (each within the scatter of the next, the first and the last beyond it).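

Working notes on the series: in this assay, 3-chlorophenyl in place of 4-nitrophenyl gives a 2.0-fold lower number from compound 2 to compound 3 (0.31 log units; beyond the scatter) and is the first step beyond the scatter at this aromatic carbon of the five-membered ring, though it is only modest. The same group in place of 4-methoxyphenyl gives a 1.3-fold lower number from compound 1 to compound 3 (0.11 log units; within the scatter) and stays within the scatter, so at this position 3-chlorophenyl is separated from 4-nitrophenyl but not from 4-methoxyphenyl. Nothing available explains this difference between the aryl groups.

As far as these compounds go, it remains open how 4-chlorophenyl, or a phenyl ring carrying an amine or a carboxylic acid, would read at this position. The rest of the shared core is the same in all three compounds, so these values say nothing about changes elsewhere.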